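Swapping fluoro for trifluoromethyl on the cytotoxicity series

A few compounds are considered here, and "the series" means these few. Any claim that something is new, unique, unknown or untested is made for them only; others in the source may bear on it.

Compound 1 `O=C(/C=C\Nc1cnc2ccccc2c1)c1nc(-c2ccc(C(F)(F)F)cc2)n2ccccc12`: > 30000 nM
Compound 2 `O=C(/C=C\Nc1ccc(Cl)cc1)c1nc(-c2ccc(F)cc2)n2ccccc12`: 5090 nM

Of the compounds shown here, two of the shared core have been tested in a functional assay on A549 cells (Homo sapiens) for cytotoxicity, read by MTT assay, with a stated time of 48 h; on this read-out higher numbers stand for weaker inhibition and lower numbers for stronger inhibition. For compound 1 the result of > 30000 nM is a limit of the assay rather than a number. Going by the values given here, compound 2 gives 5090 nM in this assay, and it is the only number in the set. The other value, that of compound 1, is a limit (the limit of > 30000 nM in this assay, at which 1 of the 2 values shown sits).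

Compound 3 `O=C(/C=C\Nc1ccc(Cl)cc1)c1nc(-c2ccc(C(F)(F)F)cc2)n2ccccc12` has not yet been measured in this assay. It differs from compound 2 in one place: trifluoromethyl in place of fluoro on an aromatic carbon. Among the compounds with values here, the group that enters is the same one carried by compound 1, but compound 1 and compound 3 also differ elsewhere, so no measured step speaks to this change on its own; one can only note that compound 1 sits at the limit while compound 2 gives a number.

Within the data shown here, with no measured step to lean on, a step from compound 2 to compound 3 of about a 2.0-fold higher number from compound 2 to compound 3 (0.29 log units; within the scatter) toward weaker inhibition is expected, with a fair chance that only a limit is reported. Compound 3 is therefore estimated at 10000 nM in this assay, within a range of 3000 nM to 30000 nM.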

Compound 3, half-maximal inhibitory concentration: 18500 nM
Compound 3: middle estimate off by 1.9-fold (0.27 log units), on the low side, within the range that was stated.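

In this assay, the change from 4-fluorophenyl to 4-(trifluoromethyl)phenyl, with 4-chlorophenyl held on the amine nitrogen, now has a measured size of its own: a 3.6-fold higher number from compound 2 to compound 3 (0.56 log units; beyond the scatter), a modest move toward weaker inhibition that lies beyond the scatter. With trifluoromethyl held in place, 4-chlorophenyl in place of quinolin-3-yl on the amine nitrogen gives an at least 1.6-fold lower number from compound 1 to compound 3 (0.20 log units; that floor lies within the scatter), so the change on that side cannot yet be told from the scatter. Compound 1 stands as a limit and not a number: the limit of > 30000 nM in this assay, at which 1 of the 3 values shown sits.

Going by these compounds, whether trifluoromethyl in place of fluoro would give a similar step with quinolin-3-yl on the amine nitrogen remains open, since a single pair of compounds speaks to this change. On these data alone, it is also open how a chloro, a methoxy or an amine on the same aromatic carbon would read in this assay, and whether the trend toward weaker inhibition follows the size of the group or something else that these few compounds cannot separate.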